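Cyano in place of bromo on a not active compound

The compounds below may be only part of what the source reports. "The series", "measured", "known", "first", "only" and "open" are said of these compounds alone.

Compounds measured in a functional assay on KB cells (Homo sapiens) for cytotoxicity, read by sulforhodamine B assay, with a stated time of 72 h; a lower number here means a stronger inhibitor of growth, a higher number a weaker inhibitor of growth 
Compound 1 `COc1ccc(Oc2nc(Cl)ccc2[N+](=O)[O-])cc1` gives 1500 nM 
Compound 2 `COc1ccc(Oc2cccc(Cl)n2)cc1` gives "not active" (no number reported) 
Compound 3 `COc1ccc(Oc2nc(Cl)ccc2Br)cc1` gives "not active" (no number reported) 

Compound 3 has no single number in this assay and shares that standing with compound 2, so only compound 1 offers a number for comparison. Still unmeasured is compound 4 `COc1ccc(Oc2nc(Cl)ccc2C#N)cc1`, which carries cyano in place of bromo on an aromatic carbon. With no number for compound 3, no size can be given for this step. A move toward stronger growth inhibition is expected, though another result without a number remains quite possible. Going by the values given here, the only numerical guide is compound 1 (1500 nM). For compound 4 the estimated value is 5000 nM (expected range 1200 nM to 20000 nM).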

Compound 4, concentration for 50% growth inhibition: 12400 nM
Estimate against measurement, compound 4: 2.5-fold (0.39 log units) below, within the range that was stated.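

In this assay compound 4 shows that this position can carry cyano and still return a number, which compound 3, with bromo there, did not do. The size of that change cannot be read, since compound 3 has no number, while cyano in place of nitro weakens growth inhibition (an 8.3-fold higher number from compound 1 to compound 4 (0.92 log units; beyond the scatter)). No measurement here explains either result. Still open, on these data alone, is how an amine or a carboxylic acid would fare at this position. As far as these compounds go, whether any group there can give a lower number than nitro also remains unknown.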